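The source may hold more compounds than are shown below. What is called first, only, known or untested is meant among the compounds shown, and "the series" means these compounds.

Measured compounds in a functional assay on PC-3 cells (Homo sapiens) for antiproliferative activity, read by MTT assay, with a stated time of 72 h; a higher number here means a weaker inhibitor, a lower number a stronger inhibitor:
- compound 1 `COc1cc2ncnc(N3CCCc4ccccc43)c2cc1NC(=O)C=C(C)C`: 6130 nM
- compound 2 `CC(C)=CC(=O)Nc1cc2c(N3CCCc4ccccc43)ncnc2cc1O[C@@H]1CCOC1`: 9020 nM

For the measured compounds named here, compound 2 carries the higher of the two numbers in this assay, but its only neighbour is compound 1, and the step of a 1.5-fold higher number from compound 1 to compound 2 (0.17 log units; within the scatter) lies within the scatter, so the two cannot be ordered. The series therefore contains a single measured change, and it concerns the ether oxygen, not the amide.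

Compound 3 `CN(C)C/C=C/C(=O)Nc1cc2c(N3CCCc4ccccc43)ncnc2cc1O[C@@H]1CCOC1` differs from compound 2 at the amide: 3-(dimethylamino)prop-1-en-1-yl in place of 2-methylprop-1-en-1-yl on a carbonyl carbon. Going by the values given here, no measured step touches the carbonyl substituent, so nothing measured bears on this change; the step of a 1.5-fold higher number from compound 1 to compound 2 (0.17 log units; within the scatter) is the only comparison available and it speaks to a different part of the molecule. With no guidance from a measured step, no direction can be claimed for the change from compound 2 to compound 3 in this assay, and the expected step is a 1.3-fold lower number from compound 2 to compound 3 (0.11 log units; within the scatter), which means no move beyond the scatter. Among the compounds with values here, the estimate for compound 3 in this assay is accordingly 7000 nM, with a range from 1500 nM to 30000 nM, anchored on compound 2 because compound 2 gives 9020 nM and no measured step points away from it.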

Compound 3, half-maximal inhibitory concentration: 4170 nM
Compound 3: middle estimate off by 1.7-fold (0.22 log units), on the high side; the range from low to high includes it.
By their numbers in this assay, from the lowest: compounds 3, 1 and 2 (each within the scatter of the next, the first and the last beyond it).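

In this assay, for the compounds shown here, the carbonyl substituent now has a measured step of its own: the change to 3-(dimethylamino)prop-1-en-1-yl from 2-methylprop-1-en-1-yl gives a 2.2-fold lower number from compound 2 to compound 3 (0.34 log units; beyond the scatter) and is the first step to pass beyond the scatter, although only modestly, whereas the earlier change on the ether oxygen could not be ordered. This position therefore responds to a substitution on the carbonyl carbon, in a direction that rests on this single pair with the oxolan-3-yl ether held constant. No measurement shown explains the shift, and the added nitrogen cannot be separated from the other differences between the two chains.

Going by these compounds, whether the same change would hold with the methyl ether of compound 1 remains open, so the two positions cannot yet be treated as independent. Going by these compounds alone, also open is how far the step depends on the terminal amine, as a diethylamino group, a morpholine ring or a longer chain carrying the dimethylamino group would show, and whether any such change would take the series beyond what the single modest step shows.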